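This account rests on a few compounds, and the source may have more. Where it says the series, first, only, none or still open, it means among the compounds named here.

Compound 1 `Cc1ccccc1NC(=O)CSc1nncnc1-c1ccccc1Cl` gives 142000 nM
Compound 2 `O=C(CSc1nncnc1-c1ccccc1Cl)Nc1ccccn1` gives 172000 nM

In an ADME assay on MT4 cells (Homo sapiens) for cytotoxicity, read by MTT assay (on this read-out lower numbers stand for higher toxicity in this test and higher numbers for lower toxicity in this test), compound 2 gives 172000 nM and sits within the scatter of compound 1. Compound 3 `O=C(CSc1nncnc1-c1ccccc1Cl)Nc1ccccc1[N+](=O)[O-]` changes the group on the amide-type nitrogen, with 2-nitrophenyl in place of pyridin-2-yl (2-nitrophenyl in place of pyridin-2-yl on an amide-type nitrogen). Among the compounds with values here, the only measured step at that place is a 1.2-fold higher number from compound 1 to compound 2 (0.08 log units; within the scatter) and it stays within the scatter. One step is thin evidence, but it gives no reason to expect a step beyond the scatter in this assay or in either direction. The expected step is a 1.1-fold lower number from compound 2 to compound 3 (0.06 log units; within the scatter). For compound 3 the estimate is 150000 nM with an expected range from 70000 nM to 300000 nM.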

Compound 3, half-maximal cytotoxic concentration: 63000 nM
The estimate for compound 3 lay 2.4-fold (0.38 log units) above the measured number; measured number outside the range, below it.
By their numbers in this assay, from the lowest: compound 3; then compounds 1 and 2 (each within the scatter of the next).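

In this assay, the group on the amide-type nitrogen can move the number beyond the scatter after all: 2-nitrophenyl in place of pyridin-2-yl gives a 2.7-fold lower number from compound 2 to compound 3 (0.44 log units; beyond the scatter). Nitro in place of methyl on an aromatic carbon points the same way, with a 2.3-fold lower number from compound 1 to compound 3 (0.35 log units; beyond the scatter), and here a lower number stands for higher toxicity in this test. Nothing measured here accounts for these steps. Going by these compounds, whether an amine or a methoxy group on that phenyl ring would also lower the number remains open.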